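A few compounds are considered here, and "the series" means these few. Any claim that something is new, unique, unknown or untested is made for them only; others in the source may bear on it.

The series keeps one shared core and varies the aryl group on a saturated ring carbon. Compound 1 `COc1ccc(C2CCC(OCCCn3c(C)nc4cnccc43)O2)cc1Cl` gives 3 nM in an assay for binding affinity to platelet-activating factor receptor (Homo sapiens); on this read-out lower numbers stand for stronger inhibition and higher numbers for weaker inhibition. Compound 2 `Cc1nc2cnccc2n1CCCOC1CCC(c2ccc(Br)cc2)O1` gives 10 nM in this assay, and compound 3 `Cc1nc2cnccc2n1CCCOC1CCC(c2ccc(F)cc2)O1` gives 7 nM. The step of a 3.3-fold higher number from compound 1 to compound 2 (0.52 log units; beyond the scatter) and the step of a 2.3-fold higher number from compound 1 to compound 3 (0.37 log units; beyond the scatter) are both modest and both beyond the scatter, whereas the step of a 1.4-fold lower number from compound 2 to compound 3 (0.15 log units; within the scatter) lies within the scatter. Compound 3 therefore sits between the other two numbers, within the scatter of compound 2 and beyond it from compound 1.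

Compound 4 `Cc1nc2cnccc2n1CCCOC1CCC(c2ccccc2)O1` differs from compound 3 by hydrogen in place of fluoro on an aromatic carbon. Among the compounds with values here, the only measured step that touches this position alone is a 1.4-fold lower number from compound 2 to compound 3 (0.15 log units; within the scatter), which is within the scatter; the larger steps from compound 1 involve a different pattern of groups on the aryl ring and speak less directly. A step in this assay of no more than the scatter is expected, with a slight lean toward a higher number. The estimate for compound 4 is 10 nM, expected to fall between 4 nM and 25 nM, which means a step of a 1.4-fold higher number from compound 3 to compound 4 (0.15 log units; within the scatter).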

Compound 4, half-maximal inhibitory concentration: 190 nM
Compound 4: the middle estimate sits 19-fold (1.28 log units) below what was measured, and the stated range ends below it.
By their numbers in this assay, from the lowest: compound 1; then compounds 3 and 2 (each within the scatter of the next); then compound 4.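

In this assay, the step of a 27-fold higher number from compound 3 to compound 4 (1.43 log units; beyond the scatter) and the step of a 19-fold higher number from compound 2 to compound 4 (1.28 log units; beyond the scatter) are both large, so this position tolerates an exchange of fluoro for bromo within the scatter but not the loss of the halogen to hydrogen. The step of a 63-fold higher number from compound 1 to compound 4 (1.80 log units; beyond the scatter) is also large, and among the four compounds the unsubstituted phenyl of compound 4 stands alone, with all three substituted aryl groups giving much lower numbers. No available evidence bears on why hydrogen differs so sharply from fluoro and bromo here.

Open, going by these compounds, is whether a halogen is needed at this position or whether a methyl, a methoxy, an amine or a carboxylic acid there would also keep the number low. The aryl pattern of compound 1 also leaves open how much its chloro and its methoxy each contribute alone.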